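Nitro to Methyl on the Amide-Side Ring

This account rests on a few compounds, and the source may have more. Where it says the series, first, only, none or still open, it means among the compounds named here.

The measured compounds and their numbers:
- compound 1, `O=C(Nc1ccccc1[N+](=O)[O-])c1ccc(/N=N\c2c[nH]c3ccccc23)cc1`: 101000 nM
- compound 2, `O=C(Nc1ccccc1Cl)c1ccc(/N=N\c2c[nH]c3ccccc23)cc1`: 112000 nM
- compound 3, `Cc1ccc(NC(=O)c2ccc(/N=N\c3c[nH]c4ccccc34)cc2)c(C)c1`: 87000 nM

All three numbers come from a functional assay on MCF7 cells (Homo sapiens) for inhibition, read by MTT assay, with a stated time of 72 h; on this read-out higher numbers stand for weaker inhibition and lower numbers for stronger inhibition. Compound 1 stands second highest of the three. The steps away from it read a 1.1-fold higher number from compound 1 to compound 2 (0.04 log units; within the scatter) and a 1.2-fold lower number from compound 1 to compound 3 (0.06 log units; within the scatter), and the remaining step reads a 1.3-fold lower number from compound 2 to compound 3 (0.11 log units; within the scatter); none of the three passes the scatter, so the three compounds cannot be ordered.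

Compound 4, `Cc1ccccc1NC(=O)c1ccc(/N=N\c2c[nH]c3ccccc23)cc1`, is not yet measured. It differs from compound 1 in one place: methyl in place of nitro on an aromatic carbon.

Two of the measured steps bear on this change. The step from compound 1 to compound 3 and the step from compound 2 to compound 3 each replace the group on the amide-type nitrogen with a methyl-bearing phenyl, and the step from compound 1 to compound 2 replaces the nitro itself; all three stay within the scatter. No step beyond the scatter is therefore expected in this assay. Compound 4 is expected to give about 92000 nM, within 46000 nM to 184000 nM, which is an expected step of a 1.1-fold lower number from compound 1 to compound 4 (0.04 log units; within the scatter).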

Compound 4, half-maximal inhibitory concentration: 73400 nM
For compound 4 the middle estimate is 1.3-fold (0.10 log units) above the measured one; the measured number falls inside the stated range.
By their numbers in this assay, from the lowest: compounds 4, 3, 1 and 2 (each within the scatter of the next).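

In this assay, nitro, chloro and methyl have now all been compared at this aromatic carbon, ortho to a large group, and the two direct swaps to methyl give a 1.4-fold lower number from compound 1 to compound 4 (0.14 log units; within the scatter) and a 1.5-fold lower number from compound 2 to compound 4 (0.18 log units; within the scatter). Neither swap passes the scatter, so this position shows no readable difference among the three groups, and methyl adds no separation that nitro and chloro had not already shown. The further change, hydrogen in place of methyl, gives a 1.2-fold lower number from compound 3 to compound 4 (0.07 log units; within the scatter), so the 2,4-dimethylphenyl and 2-methylphenyl groups cannot be told apart here either, and nothing available gives a reason for these close values.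

The compounds shown leave open whether an amine, a carboxylic acid or a longer chain at this aromatic carbon would give a step beyond the scatter. They also leave open whether any change to the shared core would do so.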